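The source may report more compounds than this note shows. Statements on the series, on what has been measured and on what is new or still open speak of the compounds shown alone.

Within the data shown here, in a functional assay on the whole organism (strain Sprague-Dawley) for inhibition, with Rattus norvegicus as the target, with a stated time of 10 min (on this read-out higher numbers stand for an effect only at larger amounts of compound and lower numbers for an effect already at smaller amounts), compound 2 `CCOC(=O)c1cnc(-c2ccccc2OC)[nH]c1=O` gives 10 mg/kg, the only actual number so far. Compound 1 `CCOC(=O)c1cnc(-c2ccccc2F)[nH]c1=O` gives > 10 mg/kg, which is a limit and not a number. Compound 3 `CCCOc1ccccc1-c1ncc(C(=O)OCC)c(=O)[nH]1` differs from compound 2 by ethyl in place of hydrogen on a saturated chain carbon bound to an oxygen on an aromatic ring, that is, methoxy to propoxy. Among the measured compounds shown here, the only measured step, a number no higher from compound 1 to compound 2 (the limit leaves the size open), has no readable size and concerns a different change, so it sets no size here. No shift beyond the scatter is therefore expected in this assay, and the expected step is no change at the digits printed from compound 2 to compound 3 (within the scatter). Compound 3 is estimated at 10 mg/kg, with an expected range of 3 mg/kg to 30 mg/kg.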

Compound 3, dose for 50% inhibition: 5 mg/kg
Estimate against measurement, compound 3: 2.0-fold (0.30 log units) above; low and high end bracket the measured number.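

In this assay, methoxy to propoxy is the first change shown at the saturated chain carbon bound to an oxygen on an aromatic ring, and it stays within the scatter: a 2.0-fold lower number from compound 2 to compound 3 (0.30 log units; within the scatter). The other new step reads an at least 2.0-fold lower number from compound 1 to compound 3 (0.30 log units; that floor lies within the scatter). Compound 1 carries a limit and not a number, so this step has a floor only: the limit of > 10 mg/kg in this assay, at which 1 of the 3 values shown sits.

As far as these compounds go, whether a longer chain than propoxy, or an amine in place of propoxy, would shift the number beyond the scatter remains open.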